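A few compounds are considered here, and "the series" means these few. Any claim that something is new, unique, unknown or untested is made for them only; others in the source may bear on it.

Within the data shown here, in an ADME assay on L929 cells (Mus musculus) for cytotoxicity, read by resazurin assay, with a stated time of 72 h (on this read-out lower numbers stand for stronger inhibition and higher numbers for weaker inhibition), only two compounds have been read so far. Compound 1 `COCOc1cccc(C(=O)/C=C/c2ccc3c(c2)B(O)OC3)c1` gives > 10 ug/mL as its result, which is a limit of the assay and not a number. Compound 2 `COc1cc(C(=O)/C=C/c2ccc3c(c2)B(O)OC3)ccc1[N+](=O)[O-]` gives > 10 ug/mL as its result, which is also a limit and not a number. Compound 2 therefore has no exact value, and the full record so far comes down to this: the limit of > 10 ug/mL in this assay, at which 2 of the 2 values shown sit, and nothing finer. The next compound is compound 3 `COc1cccc(C(=O)/C=C/c2ccc3c(c2)B(O)OC3)c1`. It differs from compound 2 by a single change (hydrogen in place of nitro on an aromatic carbon), with hydrogen in place of nitro on an aromatic carbon. Among the measured compounds shown here, no step between measured compounds is available to size such a change. The expectation rests on compound 2, whose limit of > 10 ug/mL is the nearest guide. No shift beyond the usual scatter is expected in this assay, and no direction is favoured. The expected step (a step that the limit leaves unreadable from compound 2 to compound 3) is therefore small, and another limit is the likeliest report. The estimate for compound 3 is 15 ug/mL as a value (expected range 7 ug/mL to 40 ug/mL).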

Compound 3, half-maximal inhibitory concentration: > 10 ug/mL
Compound 3: no number, only a limit (the forecaster's own chance of this, stated with the estimate: 75%); the middle value does not contradict the limit.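

In this assay, compound 3 gives only a limit, as compound 1 and compound 2 do, so its steps from those two compounds cannot be read: the limit of > 10 ug/mL in this assay, at which 3 of the 3 values shown sit. The compounds shown leave open what exact value any of the three has, and how much either single change matters on this read-out.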